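The source may report more compounds than this note shows. Statements on the series, on what has been measured and on what is new or still open speak of the compounds shown alone.

Series so far, in a functional assay on HepG2 cells (Homo sapiens) for cytotoxicity, read by MTT assay, with a stated time of 72 h; a higher number here means a weaker inhibitor, a lower number a stronger inhibitor:
compound 1 `Cc1ccc(/C=C/C=C2\CCC=CC2=O)cc1`: 8600 nM
compound 2 `O=C1C=CCC/C1=C\C=C\c1ccc(F)cc1`: 2900 nM

Among the measured compounds shown here, compound 2 holds the lower of the two numbers, and its only neighbour is compound 1. The next structure is compound 3 `O=C1C=CCC/C1=C\C=C\c1ccc(Cl)cc1`, and the change is chloro in place of fluoro on an aromatic carbon, para to a large group.

For the measured compounds named here, only one measured step bears on this: a 3.0-fold lower number from compound 1 to compound 2 (0.47 log units; beyond the scatter). That modest step, fluoro in place of methyl on an aromatic carbon, gives no direct measure of chloro. The expectation in this assay is therefore a step smaller than that one, probably within the scatter, with no firm direction.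

The estimated step is a 1.1-fold lower number from compound 2 to compound 3 (0.05 log units; within the scatter). Compound 3 is expected at about 2600 nM, with an estimated range of 1200 nM to 5600 nM.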

Compound 3, half-maximal inhibitory concentration: 3700 nM
Compound 3: middle estimate off by 1.4-fold (0.15 log units), on the low side; measured number inside the range.
By their numbers in this assay, from the lowest: compounds 2 and 3 (each within the scatter of the next); then compound 1.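

In this assay the change of chloro for fluoro on this aromatic carbon, para to a large group, gives a 1.3-fold higher number from compound 2 to compound 3 (0.11 log units; within the scatter) and so does not separate the two groups. Chloro in place of methyl gives a 2.3-fold lower number from compound 1 to compound 3 (0.37 log units; beyond the scatter) and so shows that the lower number relative to compound 1 is not confined to fluoro: compound 2 and compound 3 both stand beyond the scatter from compound 1. Nothing on hand accounts for this difference from methyl, or for the lack of one between fluoro and chloro.

The compounds shown leave open how bromo, methoxy, a nitrile or an amine at this place would compare with fluoro and chloro. They also leave open whether a carboxylic acid there would keep a number near that of compound 2.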